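Methoxy to dimethylamino on the pendant phenyl ring

The compounds below may be only part of what the source reports. "The series", "measured", "known", "first", "only" and "open" are said of these compounds alone.

Measured compounds:
compound 1, `COc1cc(-c2cc(-c3cc(C(C)C)c(O)cc3C)[nH]c(=O)c2C#N)cc(OC)c1OC`: 71% in a functional assay for inhibition, tested at 60 ug/mL; on this read-out lower numbers stand for a weaker effect and higher numbers for a stronger effect at the one concentration tested
compound 2, `COc1ccc(-c2cc(-c3cc(C(C)C)c(O)cc3C)[nH]c(=O)c2C#N)cc1`: 43% in this assay
compound 3, `COc1cc(OC)c(-c2cc(-c3cc(C(C)C)c(O)cc3C)[nH]c(=O)c2C#N)c(OC)c1`: 66% in this assay

Compound 2 stands lowest of the three numbers in this assay. Its nearest neighbour is compound 3, which lies higher by a margin beyond the scatter; compound 1 lies further above it, also beyond the scatter. Within the data shown here, the three measured compounds differ from one another in the number of methoxy groups on the pendant phenyl ring, and no pair among them isolates a single exchange, so no measured step is available as a yardstick for the change that follows.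

Compound 4, `Cc1cc(O)c(C(C)C)cc1-c1cc(-c2ccc(N(C)C)cc2)c(C#N)c(=O)[nH]1`, differs from compound 2 in one place:
dimethylamino in place of methoxy on an aromatic carbon

Among the measured compounds shown here, the measured numbers give no direct precedent for this exchange. The readings of compound 1 and compound 3 show that the shared core tolerates different substitution on this ring with inhibition that is higher, while compound 2 sits lower. A step of modest size is expected for this exchange, with a direction that cannot be fixed from the numbers shown. Compound 4 is expected to give about 50% in this assay, in a range from 30% to 70%. The expected step of a number 7 percentage points higher from compound 2 to compound 4 (within the scatter) is accordingly small, and most likely within the scatter.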

Compound 4, a percentage reported as inhibition, at one concentration (the size of the read-out at that concentration, not a potency): 53%
Estimate against measurement, compound 4: 3 percentage points below; the measured number falls inside the stated range.
By their numbers in this assay, from the lowest: compounds 2 and 4 (each within the scatter of the next); then compounds 3 and 1 (each within the scatter of the next).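

Among these compounds, the exchange of 4-methoxyphenyl for 4-(dimethylamino)phenyl gives the first comparison that differs in one place, and in this assay it reads as a number 10 percentage points higher from compound 2 to compound 4 (within the scatter). This step does not separate the two groups: at this position, on an aromatic carbon para to a large group, dimethylamino and methoxy cannot be told apart on this read-out. Nothing shown here bears on the reason for this result.

Still open, going by these compounds, is whether a primary amine, a hydroxyl group or a carboxylic acid at this position would separate from methoxy, and whether dimethylamino would read the same alongside the further methoxy groups on the pendant phenyl ring of compound 1 and compound 3. Each reading in this assay also comes from one concentration, so it gives the size of the effect at that concentration and leaves any difference in potency between compound 2 and compound 4 unresolved.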